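The source may hold more compounds than are shown below. What is called first, only, known or untested is meant among the compounds shown, and "the series" means these compounds.

Compound 2 `COC(=O)/C=C/c1cccc(N(Cc2ccc(-c3ccc(SC)cc3)cc2)C(=O)C(C)C)c1` holds the lowest of the two numbers in an assay on isolated protein with Bile acid receptor (Homo sapiens) as the target; a lower number here means that less compound is needed, a higher number that more compound is needed for the effect: compound 2 gives 51 nM. Among the compounds with values here, its only neighbour, compound 1 `COC(=O)/C=C/c1cccc(N(Cc2ccc(/C=C/c3c(Cl)cccc3Cl)cc2)C(=O)C(C)C)c1`, gives 195 nM, the one measured step being a 3.8-fold lower number from compound 1 to compound 2 (0.58 log units; beyond the scatter). Compound 3 `COC(=O)/C=C/c1cccc(N(Cc2ccc(-c3ccc(C)cc3)cc2)C(=O)C(C)C)c1` differs from compound 2 by methyl in place of methylsulfanyl on an aromatic carbon. Within the data shown here, no measured step bears on this exchange; the single known step replaces the whole outer arm rather than this one group. The number for compound 3 is therefore expected to stay within the scatter, at a 1.6-fold higher number from compound 2 to compound 3 (0.20 log units; within the scatter). Compound 3 is estimated at 80 nM, with a range from 30 nM to 250 nM.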

Compound 3, half-maximal effective concentration: 118 nM
Estimate against measurement, compound 3: 1.5-fold (0.17 log units) below; the measured number falls inside the stated range.
By their numbers in this assay, from the lowest: compound 2; then compounds 3 and 1 (each within the scatter of the next).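

Swapping methylsulfanyl alone for methyl on this aromatic carbon is a step beyond the scatter (a 2.3-fold higher number from compound 2 to compound 3 (0.36 log units; beyond the scatter)), so this one group, and not only the whole arm, bears on the number in this assay here. The 4-methylphenyl arm in place of 2-(2,6-dichlorophenyl)ethenyl gives only a step within the scatter (a 1.7-fold lower number from compound 1 to compound 3 (0.22 log units; within the scatter)), so the two compounds cannot be told apart, and only the 4-(methylsulfanyl)phenyl arm stands clear of compound 1. Nothing shown explains this difference. Going by these compounds, whether a methoxy group, an ethylsulfanyl group or an amine on the same carbon would match methylsulfanyl remains open.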